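The source may report more compounds than this note shows. Statements on the series, on what has been measured and on what is new or still open speak of the compounds shown alone.

Measured compounds:
- compound 1 `Cc1nc2ccccc2nc1Oc1ccc(C(=O)N[C@@H](CC(C)C)C(=O)O)cc1`: 19500 nM
- compound 2 `Cc1nc2cc(Cl)ccc2nc1Oc1ccc(C(=O)N[C@@H](CC(C)C)C(=O)O)cc1`: 21300 nM
- compound 3 `Cc1nc2ccc(Cl)cc2nc1Oc1ccc(C(=O)N[C@@H](CC(C)C)C(=O)O)cc1`: 14500 nM

In a functional assay on K562 cells (Homo sapiens) for antiproliferative activity, read by MTT assay, with a stated time of 48 h (a higher number here means a weaker inhibitor, a lower number a stronger inhibitor), compound 1 gives 19500 nM, the middle number of the three and within the scatter of both others. Compound 4 `CC(C)C[C@H](NC(=O)c1ccc(Oc2nc3ccccc3nc2NC(C)(C)C)cc1)C(=O)O` carries (tert-butyl)amino in place of methyl on an aromatic carbon. Among the compounds with values here, the only measured steps are chloro in place of hydrogen, a 1.1-fold higher number from compound 1 to compound 2 (0.04 log units; within the scatter) and a 1.3-fold lower number from compound 1 to compound 3 (0.13 log units; within the scatter). Within the data shown here, neither replaces the methyl, so they show only that this core has held steady so far. Among the measured compounds shown here, with no direct precedent, a modest move to a lower number is tentatively expected, and a step within the scatter remains possible: a 1.8-fold lower number from compound 1 to compound 4 (0.25 log units; within the scatter) is the estimated step. For compound 4 the estimated value is 11000 nM, with an expected range of 3500 nM to 30000 nM.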

Compound 4, half-maximal inhibitory concentration: 42300 nM
Estimate against measurement, compound 4: 3.8-fold (0.58 log units) below; measured number outside the range, above it.
By their numbers in this assay, from the lowest: compounds 3, 1, 2 and 4 (each within the scatter of the next, the first and the last beyond it).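

In this assay, within the data shown here, (tert-butyl)amino in place of methyl gives a 2.2-fold higher number from compound 1 to compound 4 (0.34 log units; beyond the scatter) and is the first change to pass the scatter, though the step is modest; both chloro steps stayed within it. This position, next to the ring nitrogen, therefore tolerates this replacement less well than the core tolerated chloro, at least for this one group. No measurement shown accounts for the step.

On these data alone, whether the nitrogen or the tert-butyl part goes with the weaker number remains open. An unsubstituted amine, methylamino or a methoxy group at this position would separate the two.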